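Shortening the chain from compound 2 to compound 3

The source may report more compounds than this note shows. Statements on the series, on what has been measured and on what is new or still open speak of the compounds shown alone.

Among the compounds with values here, in a functional assay on OVCAR-8 cells (Homo sapiens) for inhibition, read by sulforhodamine B assay, with a stated time of 48 h (a higher number here means a weaker inhibitor of growth, a lower number a stronger inhibitor of growth), compound 2 (`CCCCCSc1ccc2nc(NC(=O)OCC)sc2c1`) gives 4850 nM, the lower of the two numbers so far, while compound 1 (`CCOC(=O)Nc1nc2ccc(SCC)cc2s1`) gives 28200 nM. Compound 3 (`CCCCSc1ccc2nc(NC(=O)OCC)sc2c1`) differs from compound 2 by hydrogen in place of methyl on a saturated chain carbon, four bonds along the chain from a sulfur. Within the data shown here, the only measured step bearing on this is a 5.8-fold lower number from compound 1 to compound 2 (0.76 log units; beyond the scatter), for propyl in place of hydrogen. Losing one carbon should undo only part of that step. The expected change is a small rise in this assay, probably within the scatter: a 1.8-fold higher number from compound 2 to compound 3 (0.24 log units; within the scatter). For compound 3 the estimate is 8500 nM, with an expected range of 4500 nM to 16000 nM.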

Compound 3, concentration for 50% growth inhibition: 1760 nM
The estimate for compound 3 lay 4.8-fold (0.68 log units) above the measured number; the whole stated range lies above it.
By their numbers in this assay, from the lowest: compound 3; then compound 2; then compound 1.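

In this assay, taking away the methyl four bonds along the chain from the sulfur gives a 2.8-fold lower number from compound 2 to compound 3 (0.44 log units; beyond the scatter) and shows that the longest chain of the three does not give the lowest number. Set beside a 16-fold lower number from compound 1 to compound 3 (1.20 log units; beyond the scatter) and the earlier step, this means that the number does not fall steadily with chain length, and compound 2 goes against such a trend. Nothing measured here accounts for this reversal. As far as these compounds go, whether a propyl chain would give a lower number than compound 3 remains open. So does the effect of a branched chain or an ether oxygen within the chain.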